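A few compounds are considered here, and "the series" means these few. Any claim that something is new, unique, unknown or untested is made for them only; others in the source may bear on it.

Measured so far in a functional assay on CHO cells for agonist activity at adenosine receptor A2b (Homo sapiens), read by AlphaScreen and cAMP accumulation; a lower number here means that less compound is needed, a higher number that more compound is needed for the effect:
compound 1, `CCOc1ccc(-c2c(C#N)c(N)nc(SCC(N)=O)c2C#N)cc1` — 38 nM
compound 2, `CCOc1ccc(-c2c(C#N)c(N)nc(SCc3ncc[nH]3)c2C#N)cc1` — 11.7 nM
compound 3, `CNC(=O)CSc1nc(N)c(C#N)c(-c2ccc(OCC3CC3)cc2)c1C#N` — 94 nM

Compound 3 gives the highest number of the three in this assay. Among the compounds with values here, its nearest neighbour on the numbers is compound 1, which sits below it by a margin beyond the scatter, and the furthest is compound 2, further below; the single measured step is a 3.2-fold lower number from compound 1 to compound 2 (0.51 log units; beyond the scatter), which is a modest change made at the sulfur side of the shared core.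

Compound 4, `CCOc1ccc(-c2c(C#N)c(N)nc(SCC(=O)NC)c2C#N)cc1`, has not yet been measured. It differs from compound 3 by methyl in place of cyclopropyl on a saturated chain carbon bound to an oxygen on an aromatic ring; cut one bond further out, the change reads cyclopropylmethoxy to ethoxy. Within the data shown here, no measured pair isolates this change, so the step from compound 1 to compound 2 bears on it only as a gauge of how much the periphery of this core moves the number. What can be said is that compound 4 carries the same ethoxy group as compound 1 and compound 2, the two compounds with the lower numbers, while differing from compound 1 only in the methyl on the amide nitrogen. Compound 4 is therefore expected to land between compound 3 and compound 1, with the step estimated as a 1.7-fold lower number from compound 3 to compound 4 (0.23 log units; within the scatter). The value for compound 4 is estimated at 55 nM, in a range from 20 nM to 150 nM.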

Compound 4, half-maximal effective concentration: 211 nM
Compound 4: middle estimate off by 3.8-fold (0.58 log units), on the low side, outside the stated range (above it).
By their numbers in this assay, from the lowest: compound 2; then compound 1; then compound 3; then compound 4.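

In this assay, within the data shown here, the change from cyclopropylmethoxy to ethoxy gives a 2.2-fold higher number from compound 3 to compound 4 (0.35 log units; beyond the scatter) and is the first reading on the ether side of the shared core: with the methylcarbamoyl group held constant, cyclopropyl gives the lower number and methyl the higher. Among these compounds, the sulfur side now has two further readings, with methyl in place of hydrogen on the amide-type nitrogen giving a 5.6-fold higher number from compound 1 to compound 4 (0.74 log units; beyond the scatter) and methylcarbamoyl in place of 1H-imidazol-2-yl giving an 18-fold higher number from compound 2 to compound 4 (1.26 log units; beyond the scatter), so the amide hydrogen makes a difference that the earlier compounds could not show, and compound 4 has the highest number of the four. Nothing at hand gives a cause for any of these steps.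

Still open, going by these compounds, is whether cyclopropyl in place of methyl gives a lower number when the sulfur chain ends in carbamoyl or 1H-imidazol-2-yl, since compound 1 and compound 2 both carry ethoxy. Also open, on these data alone, are how a longer chain such as propoxy would read on the ether side and how a carboxylic acid or an amine would read at the end of the sulfur chain.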